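The source may report more compounds than this note shows. Statements on the series, on what has been measured and on what is new or still open speak of the compounds shown alone.

Compound 1, `CCCCCCCCCCCCC#CCOCc1ccc(CCC(=O)O)cc1`, and compound 2, `CCCCCCCCCCCCCCC#CCOCc1ccc(CCC(=O)O)cc1`, share one core and differ only in the length of the long saturated chain. In an assay on isolated protein for inhibition of Arachidonate 12-lipoxygenase (Sus scrofa) (on this read-out higher numbers stand for weaker inhibition and lower numbers for stronger inhibition), compound 1 gives 320 nM. For compound 2 this assay reports only a limit, > 10000 nM, so its true value is not known as a number. The step of an at least 31-fold higher number from compound 1 to compound 2 (1.49 log units; beyond the scatter) is large, and compound 2 sits at the limit of > 10000 nM in this assay, at which 1 of the 2 values shown sits, the weaker end of everything measured here.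

Compound 3, `CCCCCCCCCCCCCCC#CCOCc1ccc(C(=O)O)cc1`, is made from compound 2 by a different change: carboxy in place of 2-carboxyethyl on an aromatic carbon. The acid group stays, but the two-carbon spacer that held it away from the ring is gone. Going by the values given here, no measured step here touches this part of the molecule; the only step measured, from compound 1 to compound 2, concerns the long chain, which compound 3 keeps exactly as in compound 2. Since compound 2 is already at the limit, compound 3 is expected to show a step that the limit leaves unreadable from compound 2 to compound 3 in this assay and to remain weak. For compound 3 an estimate of 20000 nM, within 5000 nM to 80000 nM, seems reasonable, with a good chance that only a limit is reported again.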

Compound 3, half-maximal inhibitory concentration: > 10000 nM
Compound 3: no number, only a limit; the forecaster's own chance of this, stated with the estimate: 75%; the middle value does not contradict the limit.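

In this assay compound 3 gives > 10000 nM, a limit and not a number. Going by these compounds alone, compound 2 also has only a limit, so no step from compound 2 to compound 3 can be read: the limit of > 10000 nM in this assay, at which 2 of the 3 values shown sit. The compounds shown leave open whether carboxy in place of 2-carboxyethyl changes inhibition at all, for instance on the shorter chain of compound 1.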